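A few compounds are considered here, and "the series" means these few. Any claim that something is new, unique, unknown or untested is made for them only; others in the source may bear on it.

- compound 1 `CSc1ccc(NC(=O)Nc2cc(C)nc3ccccc23)cc1` with 24000 nM
- compound 2 `Cc1cc(NC(=O)Nc2ccc(C(F)(F)F)cc2)c2ccccc2n1` with 25000 nM

In an ADME assay on HEK293 cells (Homo sapiens) for cytotoxicity, with a stated time of 72 h (a lower number here means that less compound is needed, a higher number that more compound is needed for the effect), compound 2 gives 25000 nM and so stands level with compound 1 within the scatter. Compound 3 `Cc1cc(NC(=O)Nc2ccc(C(N)=O)cc2)c2ccccc2n1` has not been measured yet. It carries carbamoyl in place of trifluoromethyl on an aromatic carbon, para to a large group (carbamoyl in place of trifluoromethyl on an aromatic carbon). For the measured compounds named here, only one measured step bears on this change: a 1.0-fold higher number from compound 1 to compound 2 (0.02 log units; within the scatter) when trifluoromethyl replaced methylsulfanyl on an aromatic carbon. Going by the values given here, no compound with a carbamoyl has been measured, so this single step is only a weak guide. In this assay no step beyond the scatter is therefore expected. The expected change is a 1.2-fold higher number from compound 2 to compound 3 (0.08 log units; within the scatter) in size, with a slightly higher number as the likelier direction. For compound 3 the estimate is 30000 nM with an expected range from 14000 nM to 60000 nM in repeated measurements.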

Compound 3, half-maximal effective concentration: > 25000 nM
Compound 3 ended at the assay's limit; the forecaster's own chance of this, stated with the estimate: 30%; the middle value does not contradict the limit.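

In this assay compound 3 gives > 25000 nM, which is a limit of the assay and not a number. The limit gives a number no lower from compound 2 to compound 3 (the limit leaves the size open), and the comparison with compound 1 gives only a floor: an at least 1.0-fold higher number from compound 1 to compound 3 (0.01 log units; that floor lies within the scatter). Carbamoyl brings a hydrogen-bond donor and a hydrogen-bond acceptor to this aromatic carbon, para to a large group, where trifluoromethyl has neither, yet the number is no lower than for compound 2, and the reading stops at the limit: the limit of > 25000 nM in this assay, at which 1 of the 3 values shown sits.

On these data alone, how far the true value of compound 3 lies past this limit stays open, so any real gap between carbamoyl and trifluoromethyl remains unknown. As far as these compounds go, whether an amine or a carboxylic acid at this place would give a lower number also stays open.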